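Rearranging the side chain of a weak inhibitor

The compounds below may be only part of what the source reports. "The series", "measured", "known", "first", "only" and "open" are said of these compounds alone.

Of the compounds shown here, three sharing one core have been measured in a functional assay (brain) with Canis familiaris (Canis lupus familiaris) as the target; a higher number here means a weaker inhibitor, a lower number a stronger inhibitor. Compound 1 `COC(CNc1ccccc1)CN1CCN(CCCC(c2ccc(F)cc2)c2ccc(F)cc2)CC1` gives 15000 nM. Compound 2 `CC(=O)OC(CSc1ccccc1)CN1CCN(CCCC(c2ccc(F)cc2)c2ccc(F)cc2)CC1` gives 20000 nM, and compound 3 `COC(CSc1ccccc1)CN1CCN(CCCC(c2ccc(F)cc2)c2ccc(F)cc2)CC1` gives 20000 nM. Compound 3 thus stands level with compound 2 at the digits shown, the two together holding the highest numbers of the three, with compound 1 nearest in the other direction by a 1.3-fold higher number from compound 1 to compound 3 (0.12 log units; within the scatter). All three are weak inhibitors.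

The step from compound 3 to compound 4 `OC(CSCc1ccccc1)CN1CCN(CCCC(c2ccc(F)cc2)c2ccc(F)cc2)CC1` keeps the same atoms but joins them differently: 2-(benzylsulfanyl)-1-hydroxyethyl in place of 1-methoxy-2-(phenylsulfanyl)ethyl on a saturated chain carbon bound to an amine nitrogen in a ring. Two measured steps lead into compound 3, a 1.3-fold higher number from compound 1 to compound 3 (0.12 log units; within the scatter) and no change at the digits printed from compound 2 to compound 3 (within the scatter), and both lie within the scatter. Neither touches exactly the change at hand, but both show that reshaping this part of the side chain has so far moved the number little.

The expectation for compound 4 in this assay is therefore a step of a 1.3-fold lower number from compound 3 to compound 4 (0.12 log units; within the scatter), that is, nothing beyond the scatter. The estimated value for compound 4 is 15000 nM, with a likely range from 5000 nM to 50000 nM.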

Compound 4, half-maximal inhibitory concentration: 28000 nM
For compound 4 the middle estimate is 1.9-fold (0.27 log units) below the measured one, and the stated range covers the measured number.
By their numbers in this assay, from the lowest: compounds 1, 2, 3 and 4 (each within the scatter of the next).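

In this assay, exchanging 1-methoxy-2-(phenylsulfanyl)ethyl for 2-(benzylsulfanyl)-1-hydroxyethyl gives a 1.4-fold higher number from compound 3 to compound 4 (0.15 log units; within the scatter) and so shows that the same atoms can be joined differently here without a change beyond the scatter. Compound 1, with 2-anilino-1-methoxyethyl at the same place, gives a 1.9-fold higher number from compound 1 to compound 4 (0.27 log units; within the scatter) when that group is exchanged for 2-(benzylsulfanyl)-1-hydroxyethyl, so this second comparison also stays inside the scatter. The earlier steps shown here had covered only a change at the oxygen or a change of the atom bonded to the phenyl ring, whereas these two alter the oxygen substituent and the sulfur side together, and all four compounds remain indistinguishable at this position.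

The compounds shown leave open whether an amine or a carboxylic acid on this side chain, or a longer chain in place of the benzylsulfanyl arm, would give a step beyond the scatter, and the hydroxy and benzylsulfanyl changes cannot be told apart when they arrive together in compound 4. No supporting measurement is available to explain these results.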